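The same methylation, tried on a second core

This account rests on a few compounds, and the source may have more. Where it says the series, first, only, none or still open, it means among the compounds named here.

Compound 1 `O=C(Nc1cccc(-n2cc(-c3ccncc3)c(-c3cc(O)cc(Cl)c3)n2)c1)Nc1ccc(Cl)c(Cl)c1` gives -57.3% in a functional assay on HCT-116 cells (Homo sapiens) for inhibition, read by sulforhodamine B assay, with a stated time of 48 h, tested at 10 uM; a higher number here means a weaker effect of the compound at the concentration tested, a lower number a stronger effect. Compound 2 `COc1cc(Cl)cc(-c2nn(-c3cccc(NC(=O)Nc4ccc(Cl)c(Cl)c4)c3)cc2-c2ccncc2)c1` differs from it by methyl in place of hydrogen on an oxygen on an aromatic ring, and in this assay compound 2 gives 9.22%, so that the step of a number 66.5 percentage points higher from compound 1 to compound 2 (beyond the scatter). Compound 3 `O=C(Nc1cccc(-n2cc(-c3ccncc3)c(-c3cc(O)cc(Cl)c3)n2)c1)c1cc(C(F)(F)F)cc(C(F)(F)F)c1` rests on another core; how that core differs from the core of compound 1 is not broken down here. In this assay compound 3 gives 24.6%, the highest of the three numbers. Compound 4 `COc1cc(Cl)cc(-c2nn(-c3cccc(NC(=O)c4cc(C(F)(F)F)cc(C(F)(F)F)c4)c3)cc2-c2ccncc2)c1` has not been measured; it differs from compound 3 by methyl in place of hydrogen on an oxygen on an aromatic ring, the same change, at the same place, that leads from compound 1 to compound 2. Among the measured compounds shown here, the step of a number 66.5 percentage points higher from compound 1 to compound 2 (beyond the scatter) is the only guide. Because compound 3 already starts at 24.6%, a smaller rise is expected for compound 4, a number 40.4 percentage points higher from compound 3 to compound 4 (beyond the scatter). Compound 4 is therefore estimated at 65%, between 35% and 95%.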

Compound 4, a percentage reported as activity, at one concentration (the size of the read-out at that concentration, not a potency): 35.2%
Compound 4: the middle estimate sits 29.8 percentage points above what was measured; the range from low to high includes it.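

In this assay the change from hydroxy to methoxy again moves the read-out the same way, a number 10.6 percentage points higher from compound 3 to compound 4 (beyond the scatter). The direction of the step carried over from one core to the other, but its size did not: the same change on two cores in this assay, a number 66.5 percentage points higher (beyond the scatter) from compound 1 to compound 2 and a number 10.6 percentage points higher (beyond the scatter) from compound 3 to compound 4, 55.9 percentage points apart, beyond the scatter of two such steps These two pairs show that the step cannot be transferred between these cores at a fixed size; they do not show which feature of the cores goes with the difference, or what the change would do on any further core.

The compounds shown carry only hydroxy or methoxy at this place on the 3-chlorophenyl ring. On these data alone, how an amine, a carboxylic acid or a longer chain such as ethoxy would read there on either core remains open.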